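The source may hold more compounds than are shown below. What is called first, only, known or untested is meant among the compounds shown, and "the series" means these compounds.

Measured so far:
Compound 1, `Cc1ccccc1CN1CCc2c(sc(NC(=O)c3ccccc3Cl)c2C(N)=O)C1`. In a functional assay on HeLa cells (Homo sapiens) for antiproliferative activity, with a stated time of 24 h (a lower number here means a stronger inhibitor, a higher number a weaker inhibitor), compound 1 gives only a limit, > 50000 nM.
Compound 2, `NC(=O)c1c(NC(=O)c2ccccc2Cl)sc2c1CCN(Cc1c(Cl)cccc1Cl)C2`. In this assay compound 2 gives 28800 nM.

Going by the values given here, compound 2 thus holds the only true number here, since the other result is a limit (the limit of > 50000 nM in this assay, at which 1 of the 2 values shown sits). Compound 3, `NC(=O)c1c(NC(=O)c2ccccc2Cl)sc2c1CCN(C(=S)Nc1ccccc1F)C2`, differs from compound 2 by a group of 10 heavy atoms (7 carbon, 1 nitrogen, 1 fluorine, 1 sulfur; one six-membered aromatic ring of carbon only) in place of a group of 9 heavy atoms (7 carbon, 2 chlorine; one six-membered aromatic ring of carbon only), on an amine nitrogen in a ring. Among the compounds with values here, the single measured step, an at least 1.7-fold lower number from compound 1 to compound 2 (0.23 log units; that floor lies within the scatter), sits on the same ring nitrogen but swaps one aromatic group for another, and its floor lies within the scatter, so it says little about a move from a benzyl to a thiourea-type group. No direction can be derived; the expected outcome for compound 3 is a result near that of compound 2, with a wide spread and a real chance of another limit. Compound 3 is therefore estimated at 30000 nM, between 8000 nM and 100000 nM, and the expected step is a 1.0-fold higher number from compound 2 to compound 3 (0.02 log units; within the scatter).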

Compound 3, half-maximal inhibitory concentration: 28700 nM
For compound 3 the middle estimate is 1.0-fold (0.02 log units) above the measured one; the range from low to high includes it.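

On the amine nitrogen in a ring, the 2,6-dichlorobenzyl group can be exchanged for a group that contains sulfur and fluorine and has 1 hydrogen-bond donor and 1 hydrogen-bond acceptor, with no readable difference in this assay: a 1.0-fold lower number from compound 2 to compound 3 (0.00 log units; within the scatter). A benzyl group is therefore not needed at this position for the activity seen in compound 2 and compound 3. The comparison with the 2-methylbenzyl compound gives an at least 1.7-fold lower number from compound 1 to compound 3 (0.24 log units; that floor lies within the scatter), so it cannot show a real difference, and it rests on a limit rather than a number: the limit of > 50000 nM in this assay, at which 1 of the 3 values shown sits.

As far as these compounds go, whether anything on this nitrogen can move the number beyond the scatter remains open. A small methyl group, a chain ending in an amine or a carboxylic acid on the aromatic ring could each test this.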